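Benzoyl in Place of Cyclobutylcarbonyl on a Nitrofuran Amide

The compounds below may be only part of what the source reports. "The series", "measured", "known", "first", "only" and "open" are said of these compounds alone.

Compound 3, `O=C(Nc1nc(-c2cccc(NC(=O)C3CCC3)c2)cs1)c1ccc([N+](=O)[O-])o1`, has no number in an ADME assay on Vero cells (Chlorocebus sabaeus) for cytotoxicity, read by MTT assay, with a stated time of 72 h; on this read-out higher numbers stand for weaker inhibition and lower numbers for stronger inhibition; for compound 3 the result in this assay is simply "not determined" (no result reported). Its two measured relatives set the frame. Compound 1, `O=C(Nc1nc(-c2cccc(Cl)c2)cs1)c1ccc([N+](=O)[O-])o1`, gives 43700 nM in this assay. Compound 2, `CCOc1cccc(-c2csc(NC(=O)c3ccc([N+](=O)[O-])o3)n2)c1`, gives > 90000 nM in this assay, and that is a limit of the assay rather than a number. Within the data shown here, the one measured step, an at least 2.0-fold higher number from compound 1 to compound 2 (0.31 log units; beyond the scatter), is therefore open-ended because the limit of > 90000 nM in this assay, at which 1 of the 3 values shown sits, caps what could be read. Compound 4, `O=C(Nc1cccc(-c2csc(NC(=O)c3ccc([N+](=O)[O-])o3)n2)c1)c1ccccc1`, differs from compound 3 by phenyl in place of cyclobutyl on a carbonyl carbon. Among the measured compounds shown here, no measured step touches that change: the step from compound 1 to compound 2 swaps a group on the aromatic ring of the shared core, not on the carbonyl carbon. The expectation for compound 4 in this assay thus rests only on where the two measured compounds sit, namely the weak end of the scale, with no direction of shift to predict beyond the scatter. Compound 4 is estimated at 60000 nM in this assay, within a range of 25000 nM to 150000 nM, with a fair chance that only a limit is reported.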

Compound 4, half-maximal inhibitory concentration: 50200 nM
Compound 4: middle estimate off by 1.2-fold (0.08 log units), on the high side; the measured number falls inside the stated range.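

In this assay, benzamido in place of chloro on this aromatic carbon gives a 1.1-fold higher number from compound 1 to compound 4 (0.06 log units; within the scatter), so an aromatic amide on that carbon yields a measured number that cannot be told apart from the one with chloro. Compound 2 gives > 90000 nM in this assay, which is a limit of the assay and not a number. Benzamido in place of ethoxy gives an at least 1.7-fold lower number from compound 2 to compound 4 (0.25 log units; that floor lies within the scatter), and this comparison remains open-ended, with a floor that does not clear the scatter, because one end of it is such a limit: the limit of > 90000 nM in this assay, at which 1 of the 4 values shown sits.

Among these compounds, no step to compound 3 can be read, so what phenyl in place of cyclobutyl does on the carbonyl carbon remains open. Also open, from the compounds shown here alone, is how an amine or a carboxylic acid on the aromatic carbon that carries benzamido in compound 4, or a longer chain in place of phenyl on the carbonyl carbon, would read in this assay.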